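Swapping the Ring on the Piperazine Nitrogen: Compound 3 Expected

The source may hold more compounds than are shown below. What is called first, only, known or untested is meant among the compounds shown, and "the series" means these compounds.

Compound 2 `Nc1scc(CN2CCN(C3CCCCCC3)CC2)c1C(=O)c1ccc(Cl)cc1` was tested in a functional assay on CHO cells with adenosine receptor A1 (Homo sapiens) as the target, read by cAMP accumulation and immunoassay, with a stated time of 6 min, tested at 1 uM (a higher number here means a weaker effect of the compound at the concentration tested, a lower number a stronger effect), and gave 3.7%. Within the data shown here, compound 1 `Nc1scc(CN2CCN(c3cccnc3)CC2)c1C(=O)c1ccc(Cl)cc1` gave -2.7% in this assay; the step of a number 6.4 percentage points higher from compound 1 to compound 2 (within the scatter) is within the scatter, so the two compounds cannot be ordered, and compound 2 stands with compound 1 as the only other number to compare against. Compound 3 `Nc1scc(CN2CCN(c3ccc(F)cc3F)CC2)c1C(=O)c1ccc(Cl)cc1` has not yet been measured in this assay. It differs from compound 2 in this way: 2,4-difluorophenyl in place of cycloheptyl on an amine nitrogen in a ring. Among the measured compounds shown here, the one measured step bears on this change only loosely, since it shows that replacing pyridin-3-yl by cycloheptyl at this position left the read-out unchanged beyond the scatter; there is no measured step that exchanges cycloheptyl for a difluorophenyl ring. Compound 3 is therefore expected to sit near its neighbours, at an estimated 0%, with a range from -12% to 12%, which means an expected step of a number 3.7 percentage points lower from compound 2 to compound 3 (within the scatter).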

Compound 3, a percentage reported as activity, at one concentration (the size of the read-out at that concentration, not a potency): -66%
Estimate against measurement, compound 3: 66 percentage points above; the whole stated range lies above it.
By their numbers in this assay, from the lowest: compound 3; then compounds 1 and 2 (each within the scatter of the next).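

In this assay, the position on the amine nitrogen in a ring proved able to change the read-out strongly, which the earlier pair had not shown: 2,4-difluorophenyl in place of cycloheptyl gives a number 69.7 percentage points lower from compound 2 to compound 3 (beyond the scatter), and in place of pyridin-3-yl it gives a number 63.3 percentage points lower from compound 1 to compound 3 (beyond the scatter). Since compound 1 also carries a six-membered aromatic ring at this position, among these three compounds such a ring alone does not go with the stronger effect at the concentration tested. Nothing available explains the size of this change.

The compounds shown leave open whether both fluorine atoms are needed, or whether a single fluorine would do. A plain phenyl ring, or a phenyl ring carrying chlorine or methoxy, would separate the part played by the ring from that of its fluorine atoms.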